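The source may hold more compounds than are shown below. What is called first, only, known or untested is meant among the compounds shown, and "the series" means these compounds.

For the measured compounds named here, in an assay on isolated protein for inhibition of histone deacetylase 8 (Homo sapiens) (a lower number here means a stronger inhibitor, a higher number a weaker inhibitor), compound 3 `O=C(CCCCCCCC(=O)c1ccc(-c2ccccc2)cc1)NO` gives 5 nM, the lowest of the three numbers measured so far. Compound 1 `O=C(CCCCCCCC(=O)c1ccc(C(F)(F)F)cc1)NO` gives 45 nM in this assay, and compound 2 `O=C(CCCCCCCC(=O)c1ccc(Br)cc1)NO` gives 45 nM. There is no change at the digits printed from compound 1 to compound 2 (within the scatter), whereas there is a 9.0-fold lower number from compound 1 to compound 3 (0.95 log units; beyond the scatter) and a 9.0-fold lower number from compound 2 to compound 3 (0.95 log units; beyond the scatter). Compound 4 `O=C(CCCCCCCC(=O)c1ccc(N2CCCCC2)cc1)NO` differs from compound 3 by piperidin-1-yl in place of phenyl on an aromatic carbon. Going by the values given here, both measured steps that lead to compound 3 exchange a small group for phenyl; no measured step exchanges phenyl for a six-membered non-aromatic ring with one hetero atom, so these steps bear on the new change only indirectly. A modest rise of the number is therefore expected, a 3.0-fold higher number from compound 3 to compound 4 (0.48 log units; beyond the scatter). Compound 4 is estimated at 15 nM in this assay, with a range from 4 nM to 60 nM.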

Compound 4, half-maximal inhibitory concentration: 9.5 nM
For compound 4 the middle estimate is 1.6-fold (0.20 log units) above the measured one; measured number inside the range.
By their numbers in this assay, from the lowest: compounds 3 and 4 (each within the scatter of the next); then compounds 1 and 2 (each within the scatter of the next).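

In this assay, the step of a 1.9-fold higher number from compound 3 to compound 4 (0.28 log units; within the scatter) shows that on this aromatic carbon a non-aromatic ring holding nitrogen can take the place of phenyl without a change beyond the scatter. Aromatic phenyl is therefore not the only group here that gives a number well under those of the smaller groups, as a 4.7-fold lower number from compound 2 to compound 4 (0.68 log units; beyond the scatter) and a 4.7-fold lower number from compound 1 to compound 4 (0.68 log units; beyond the scatter) show. No evidence is available to explain these differences. Still open, as far as these compounds go, is whether cyclohexyl, which lacks the ring nitrogen, or morpholin-4-yl, which adds ring oxygen, would behave like piperidin-1-yl at this place.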